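Replacing a Sulfonyl Aryl Group with a Chlorobenzyl Group

A few compounds are considered here, and "the series" means these few. Any claim that something is new, unique, unknown or untested is made for them only; others in the source may bear on it.

Compound 3 `Cc1ccc(S(=O)(=O)/C(=C/c2ccc(C)s2)C(=O)c2ccc(Cl)cc2)cc1` gives 50000 nM in a functional assay on DU-145 cells (Homo sapiens) for inhibition, read by trypan blue exclusion, with a stated time of 96 h (a lower number here means a stronger inhibitor of growth, a higher number a weaker inhibitor of growth), the highest of the three numbers measured, with compound 1 `Cc1ccc(/C=C(\C(=O)c2ccc(Cl)cc2)S(=O)(=O)Cc2ccc(Cl)cc2Cl)s1` at 10000 nM and compound 2 `CSc1ccc(/C=C(\C(=O)c2ccc(Cl)cc2)S(=O)(=O)Cc2ccc(Cl)cc2)cc1` at 10000 nM. Compound 4 `Cc1ccc(/C=C(\C(=O)c2ccc(Cl)cc2)S(=O)(=O)Cc2ccc(Cl)cc2)s1` differs from compound 3 in one place: 4-chlorobenzyl in place of 4-methylphenyl on a sulfonyl sulfur. Within the data shown here, the only step that bears on this change is a 5.0-fold higher number from compound 1 to compound 3 (0.70 log units; beyond the scatter), and the new compound 4 reverses that direction by returning to a benzyl group on the sulfonyl sulfur. Compound 2 carries the same 4-chlorobenzyl group and sits at the lower value. A downward step beyond the scatter is therefore expected, a 4.2-fold lower number from compound 3 to compound 4 (0.62 log units; beyond the scatter). Compound 4 is estimated at 12000 nM, within a range of 5000 nM to 30000 nM.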

Compound 4, concentration for 50% growth inhibition: 1000 nM
The estimate for compound 4 lay 12-fold (1.08 log units) above the measured number, and the stated range ends above it.
By their numbers in this assay, from the lowest: compound 4; then compounds 1 and 2 (each within the scatter of the next); then compound 3.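

Within this assay the group on the sulfonyl sulfur matters more than the earlier compounds showed: a 50-fold lower number from compound 3 to compound 4 (1.70 log units; beyond the scatter) comes with 4-chlorobenzyl in place of 4-methylphenyl. The benzyl group also does better without its extra chloro, since a 10-fold lower number from compound 1 to compound 4 (1.00 log units; beyond the scatter) comes with hydrogen in place of chloro on an aromatic carbon. The 5-methylthiophen-2-yl group also counts, with a 10-fold lower number from compound 2 to compound 4 (1.00 log units; beyond the scatter) following from its replacing 4-(methylsulfanyl)phenyl.

Going by these compounds, whether a 4-methoxybenzyl or a phenethyl group on the sulfonyl sulfur would hold this level remains open. No measurement shown explains these steps.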